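A few compounds are considered here, and "the series" means these few. Any claim that something is new, unique, unknown or untested is made for them only; others in the source may bear on it.

Measured in an ADME assay on MT4 cells (Homo sapiens) for cytotoxicity, read by MTT assay; a higher number here means that more compound is tolerated, a lower number that less compound is tolerated:
Compound 1 `Cc1ccc(-[n+]2noc([O-])c2CN2CCN(c3cccc(Cl)c3Cl)CC2)cc1`: 31.7 ug/mL
Compound 2 `[O-]c1on[n+](-c2ccc(Cc3ccc(-[n+]4noc([O-])c4CN4CCN(c5cccc(Cl)c5Cl)CC4)cc3)cc2)c1CN1CCN(c2cccc(Cl)c2Cl)CC1`: 20.8 ug/mL
Compound 3 `[O-]c1on[n+](-c2ccc(Cc3ccc(-[n+]4noc([O-])c4CN4CCN(c5ccccc5)CC4)cc3)cc2)c1CN1CCN(c2ccccc2)CC1`: 10.3 ug/mL

Compound 1 and compound 2 cannot be told apart within the scatter of this measurement, while compound 3 lies lower than compound 1, beyond the scatter.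

Compound 4 `Cc1ccc(-[n+]2noc([O-])c2CN2CCNCC2)cc1` has hydrogen in place of 2,3-dichlorophenyl on an amine nitrogen in a ring. Going by the values given here, no measured compound has a bare hydrogen at this place, so the data offer no direct comparison, and any expectation here is tentative. Starting from compound 1 at 31.7 ug/mL, a rise beyond the scatter in this assay is expected, which makes the expected step of a 1.7-fold higher number from compound 1 to compound 4 (0.24 log units; within the scatter). For compound 4 the estimated value is 55 ug/mL, within an expected range of 22 ug/mL to 120 ug/mL.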

Compound 4, half-maximal cytotoxic concentration: 32.6 ug/mL
For compound 4 the middle estimate is 1.7-fold (0.23 log units) above the measured one, and the stated range covers the measured number.
By their numbers in this assay, from the lowest: compound 3; then compounds 2, 1 and 4 (each within the scatter of the next).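

In this assay, hydrogen in place of 2,3-dichlorophenyl on an amine nitrogen in a ring gives a 1.0-fold higher number from compound 1 to compound 4 (0.01 log units; within the scatter). Going by these compounds alone, this is the first comparison here of two compounds that differ in one place, and it shows that in this pair, losing the whole aromatic group leaves the tolerated concentration indistinguishable. No available evidence bears on this result.

From the compounds shown here alone, whether smaller or different groups on this nitrogen, such as methyl, benzyl or acetyl, would also fall within the scatter remains open.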